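From 1H-benzimidazol-2-yl to 1,3-benzoxazol-2-yl

The compounds below may be only part of what the source reports. "The series", "measured", "known", "first", "only" and "open" are said of these compounds alone.

Compound 1 `CCn1cc(-c2nc3ccccc3[nH]2)c(=O)c2cc(F)c(N3CCNCC3)nc21`: 4800 nM
Compound 2 `CCn1cc(-c2nc3ccccc3[nH]2)c(=O)c2cc(F)c(N3CCNC(C)C3)c(F)c21`: 11600 nM

Among the measured compounds shown here, in a functional assay on A2780 cells (Homo sapiens) for cytotoxicity, read by MTT assay, with a stated time of 48 h (a higher number here means a weaker inhibitor, a lower number a stronger inhibitor), compound 1 gives 4800 nM, the lower of the two numbers so far, while compound 2 gives 11600 nM, and the gap between them lies beyond the scatter. For the measured compounds named here, these two compounds differ in more than one place, so they give no clean single-change step to learn from.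

Compound 3 `CCn1cc(-c2nc3ccccc3o2)c(=O)c2cc(F)c(N3CCNCC3)nc21` keeps the core of compound 1 and changes one group: 1,3-benzoxazol-2-yl stands in place of 1H-benzimidazol-2-yl on an aromatic carbon. The count is 1,3-benzoxazol-2-yl in place of 1H-benzimidazol-2-yl on an aromatic carbon.

Going by the values given here, no measured pair shows this swap, so the expectation is only a small move towards weaker inhibition, perhaps none beyond the scatter. The estimated change is a 1.3-fold higher number from compound 1 to compound 3 (0.10 log units; within the scatter). For compound 3, the expected value is 6000 nM, with an estimated range of 2000 nM to 18000 nM.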

Compound 3, half-maximal inhibitory concentration: 15300 nM
Beside the measured number, compound 3's estimate is 2.6-fold (0.41 log units) below it; the measured number falls inside the stated range.
By their numbers in this assay, from the lowest: compound 1; then compounds 2 and 3 (each within the scatter of the next).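

In this assay, among the compounds shown here, putting 1,3-benzoxazol-2-yl in place of 1H-benzimidazol-2-yl on the aromatic carbon gives a 3.2-fold higher number from compound 1 to compound 3 (0.50 log units; beyond the scatter), the first clean single-change step in this set. This position is therefore sensitive to a swap that keeps the heavy-atom count and ring types the same, while the group that leaves has a hydrogen-bond donor and the group that enters has none. No measurement shown here accounts for the rise in the number.

On these data alone, whether that lost donor matters remains open, and a 1-methylbenzimidazol-2-yl or 1,3-benzothiazol-2-yl group at the same position would help separate the possibilities. As far as these compounds go, it also remains open whether the same swap would move the number similarly on the core of compound 2.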